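Cyclopentyl to pentyl on the ring amine nitrogen

The source may hold more compounds than are shown below. What is called first, only, known or untested is meant among the compounds shown, and "the series" means these compounds.

Compound 1 `COc1cc(N)c(Cl)cc1NC(=O)C1CCN(Cc2ccc(F)cc2)CC1` gives 0.6 mg/kg in a functional assay on the whole organism for antagonist activity, with Mus musculus as the target; on this read-out higher numbers stand for an effect only at larger amounts of compound and lower numbers for an effect already at smaller amounts. Compound 2 `COc1cc(N)c(Cl)cc1NC(=O)C1CCN(CC2CCCC2)CC1` reaches only a limit of the assay, > 10 mg/kg, in this assay. Compound 3 `COc1cc(N)c(Cl)cc1NC(=O)C1CCN(C2CCCC2)CC1` likewise stops at a limit, > 10 mg/kg, in this assay, so only a limit is known for it (the limit of > 10 mg/kg in this assay, at which 2 of the 3 values shown sit). The measured steps of an at least 16-fold higher number from compound 1 to compound 2 (1.22 log units; beyond the scatter) and an at least 16-fold higher number from compound 1 to compound 3 (1.22 log units; beyond the scatter) are both large, while the step that the two limits leave unreadable from compound 2 to compound 3 cannot be read. Compound 4 `CCCCCN1CCC(C(=O)Nc2cc(Cl)c(N)cc2OC)CC1` differs from compound 3 by pentyl in place of cyclopentyl on an amine nitrogen in a ring. For the measured compounds named here, no measured step exchanges a cyclopentyl for a pentyl. Both saturated groups, on compound 2 and compound 3, gave limits, so for compound 4 a step that the limit leaves unreadable from compound 3 to compound 4 is expected, most likely again ending at a limit. The estimate for compound 4 is 15 mg/kg, between 4 mg/kg and 50 mg/kg.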

Compound 4, dose for half-maximal effect: > 10 mg/kg
Compound 4: a limit, no number (the forecaster's own chance of this, stated with the estimate: 70%); the middle value does not contradict the limit.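

In this assay compound 4 also ends at a limit, > 10 mg/kg. Opening the cyclopentyl ring to a pentyl chain therefore does not bring back a measurable dose, and the 4-fluorobenzyl group of compound 1 remains the only group shown with a number, with an at least 16-fold higher number from compound 1 to compound 4 (1.22 log units; beyond the scatter). The steps among compound 2, compound 3 and compound 4 cannot be read: the limit of > 10 mg/kg in this assay, at which 3 of the 4 values shown sit.

On these data alone, how far the three saturated groups differ beyond the limit stays open. So does whether the effect needs the fluorine, which an unsubstituted benzyl or a 4-chlorobenzyl group could show.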